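The source may hold more compounds than are shown below. What is called first, only, known or untested is meant among the compounds shown, and "the series" means these compounds.

Measured compounds:
- compound 1, `NC(=O)/C=C/c1ccncc1-c1ccc2ccccc2c1`: 102%
- compound 2, `CNC(=O)/C=C/c1ccncc1-c1ccc2[nH]ccc2c1`: 100%

Both were tested in an assay on a protein complex for inhibition of CDK8/Cyclin C (Homo sapiens), with a stated time of 1 h, tested at 10 uM; a higher number here means more inhibition at the concentration tested (going by the name of the read-out), a lower number less inhibition. Compound 1 gives 102% in this assay, and compound 2 gives 100%; the two numbers lie within the usual scatter of one another, so neither can be set apart from the other, and both numbers are level and high in this assay.

Compound 3, `COC(=O)/C=C/c1ccncc1-c1ccc2ccccc2c1`, has not yet been measured. It differs from compound 1 in one place: methoxy in place of amino on a carbonyl carbon. Going by the values given here, with only two measured compounds, both with high and level numbers, no step of this kind has been measured. The expectation is that the step of a number 17 percentage points lower from compound 1 to compound 3 (beyond the scatter) is a modest loss, since a read-out this high leaves little room to rise. Compound 3 is therefore estimated at 85%, with a likely range from 40% to 102%.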

Compound 3, a percentage reported as inhibition, at one concentration (the size of the read-out at that concentration, not a potency): 102%
Beside the measured number, compound 3's estimate is 17 percentage points below it; measured number inside the range.
By their numbers in this assay, from the lowest: compounds 2, 1 and 3 (each within the scatter of the next).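

In this assay, methoxy in place of amino on a carbonyl carbon gives no change at the digits printed from compound 1 to compound 3 (within the scatter), so this position does not need the amino group for a high read-out at the concentration tested. Going by these compounds alone, the change removes a hydrogen-bond donor, adds a hydrogen-bond acceptor and replaces the amide of compound 1 with the ester of compound 3, yet the number holds, which the earlier compounds could not show because no step had been measured. Nothing available gives a reason for this result.

As far as these compounds go, a single concentration gives the size of a read-out and not a potency, so any difference between compound 1 and compound 3 at lower concentrations stays open. Also open, from the compounds shown here alone, is how this position responds to a carboxylic acid, a dimethylamino group or a longer chain such as ethoxy.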